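Replacing 2,4-difluorophenyl with pyridin-3-yl

The source may hold more compounds than are shown below. What is called first, only, known or untested is meant among the compounds shown, and "the series" means these compounds.

- compound 1 `COC1=CC(=O)c2c(COc3ccc(F)cc3)c(C)n(C)c2C1=O`: 493 nM
- compound 2 `COC1=CC(=O)c2c(COc3ccc(F)cc3F)c(C)n(C)c2C1=O`: 75 nM

For the measured compounds named here, in a functional assay on MIA PaCa-2 cells (Homo sapiens) for cytotoxicity, read by MTT assay, with a stated time of 72 h (a higher number here means a weaker inhibitor, a lower number a stronger inhibitor), compound 2 has the lowest of the two numbers so far, 75 nM, which makes it the stronger inhibitor of the pair. The next compound is compound 3 `COC1=CC(=O)c2c(COc3cccnc3)c(C)n(C)c2C1=O`, with pyridin-3-yl in place of 2,4-difluorophenyl on an oxygen on a saturated carbon.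

Going by the values given here, only one measured step bears on this change. In a 6.6-fold lower number from compound 1 to compound 2 (0.82 log units; beyond the scatter), fluoro replaces hydrogen on an aromatic carbon. Compound 3 carries no fluorine, and with less fluorine than compound 2, compound 1 gives 493 nM. A step of similar size towards a higher number is therefore expected in this assay. Among the compounds with values here, no measured compound shows what the ring nitrogen does, so the range stays wide. The expected change is an 8.0-fold higher number from compound 2 to compound 3 (0.90 log units; beyond the scatter). Compound 3 is estimated at 600 nM, with an expected range from 150 nM to 2400 nM.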

Compound 3, half-maximal inhibitory concentration: 1820 nM
Compound 3: the middle estimate sits 3.0-fold (0.48 log units) below what was measured; the range from low to high includes it.
By their numbers in this assay, from the lowest: compound 2; then compound 1; then compound 3.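

In this assay the ring on this oxygen proves able to shift the number by more than the fluorine step alone showed, with a 24-fold higher number from compound 2 to compound 3 (1.39 log units; beyond the scatter) when pyridin-3-yl replaces 2,4-difluorophenyl. Pyridin-3-yl also falls short of 4-fluorophenyl, with a 3.7-fold higher number from compound 1 to compound 3 (0.57 log units; beyond the scatter) in this comparison, so compound 3 is the weakest of the three and the ring with nitrogen and no fluorine ranks behind both fluorinated phenyl rings. No measurement here explains why this change weakens the compound so much.

The compounds shown leave open whether the ring nitrogen or the loss of fluorine accounts for the rise, which a plain phenyl ring or a fluorinated pyridin-3-yl would help to separate. From the compounds shown here alone, how a saturated ring such as cyclohexyl would fare on this oxygen also remains open.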